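Swapping the halogenated ring on the sulfur of compound 2

The source may hold more compounds than are shown below. What is called first, only, known or untested is meant among the compounds shown, and "the series" means these compounds.

Measured so far:
- compound 1 `Nc1cc(N)c2nc(-c3ccccc3)c(NCc3ccc(Cl)c(Cl)c3)nc2c1`: 2140 nM
- compound 2 `Nc1cc(N)c2nc(-c3ccccc3)c(Sc3ccc(F)cc3)nc2c1`: 22900 nM
- compound 3 `COc1cc(CNc2nc3cc(N)cc(N)c3nc2-c2ccccc2)cc(OC)c1OC`: 3160 nM

These three compounds share one core and were tested in a functional assay on LOX IMVI cells (Homo sapiens) for inhibition, read by sulforhodamine B assay, with a stated time of 48 h; on this read-out lower numbers stand for stronger inhibition of growth and higher numbers for weaker inhibition of growth. Among them compound 2 gives the highest number, 22900 nM, so it inhibits growth the least; compound 3 and compound 1 both give lower numbers, and both gaps lie beyond the scatter of repeated measurements.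

Compound 4 `Nc1cc(N)c2nc(-c3ccccc3)c(Sc3ccc(Cl)c(Cl)c3)nc2c1` is not yet measured. It differs from compound 2 in one place: 3,4-dichlorophenyl in place of 4-fluorophenyl on a sulfur. Among the measured compounds shown here, no pair among the measured compounds differs by just this change, so there is no directly comparable step to lean on. Compound 1 does carry a 3,4-dichlorophenyl ring, though attached through a different linker, and gives 2140 nM, a lower number than compound 2. On that slender basis the step of a 2.9-fold lower number from compound 2 to compound 4 (0.46 log units; beyond the scatter) is expected to bring a moderately lower number, probably beyond the scatter, though with wide uncertainty. Compound 4 is therefore estimated at 8000 nM, within a range from 2500 nM to 25000 nM.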

Compound 4, concentration for 50% growth inhibition: 7410 nM
Compound 4: the middle estimate sits 1.1-fold (0.03 log units) above what was measured; the measured number falls inside the stated range.
By their numbers in this assay, from the lowest: compounds 1 and 3 (each within the scatter of the next); then compound 4; then compound 2.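

In this assay, replacing 4-fluorophenyl with 3,4-dichlorophenyl on the sulfur gives a 3.1-fold lower number from compound 2 to compound 4 (0.49 log units; beyond the scatter) and shows that the number responds to the ring carried at this position. Among the compounds shown here, this modest step is the first in the set that can be read as a single change, as no earlier pair differed in only one place. No measurement at hand gives a reason for the shift.

The compounds shown leave open whether one chlorine alone would give a similar step, or whether both chlorines are needed. Going by these compounds, it also remains open how the number would move with a carboxylic acid or an aminoethyl chain on the ring attached to the sulfur.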